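Aryl Groups on the Terminal Piperazine and Cytotoxicity

The source may report more compounds than this note shows. Statements on the series, on what has been measured and on what is new or still open speak of the compounds shown alone.

Compound 3 `C#CCN1CCN(CC(=O)N2CCN(c3ccc(C(=O)c4cc5ccc(N(CC)CC)cc5o4)cc3)CC2)CC1` sits at a limit in an ADME assay on L02 cells (Homo sapiens) for cytotoxicity, read by MTT assay, with a stated time of 48 h (a higher number here means a weaker inhibitor, a lower number a stronger inhibitor), giving > 100000 nM. Compound 1 `CCN(CC)c1ccc2cc(C(=O)c3ccc(N4CCN(C(=O)CN5CCNCC5)CC4)cc3)oc2c1` also sits at a limit, giving > 100000 nM. Within the data shown here, compound 2 `CCN(CC)c1ccc2cc(C(=O)c3ccc(N4CCN(C(=O)CN5CCN(S(=O)(=O)c6ccc(C#N)cc6)CC5)CC4)cc3)oc2c1` is the only one with a number, giving 44100 nM. Of the steps, an at least 2.2-fold lower number from compound 1 to compound 2 (0.35 log units; beyond the scatter) and an at least 2.2-fold higher number from compound 2 to compound 3 (0.35 log units; beyond the scatter) are readable, while a step that the two limits leave unreadable from compound 1 to compound 3 is not, because of the limit of > 100000 nM in this assay, at which 2 of the 3 values shown sit. Compound 4 `CCN(CC)c1ccc2cc(C(=O)c3ccc(N4CCN(C(=O)CN5CCN(Cc6ccc(F)c(F)c6)CC5)CC4)cc3)oc2c1` carries 3,4-difluorophenyl in place of ethynyl on a saturated chain carbon bound to an amine nitrogen in a ring. Since the aryl group of compound 2 brought a number in this assay, an aryl group on compound 4 is expected to do likewise, with a step of an at least 2.0-fold lower number from compound 3 to compound 4 (0.30 log units; that floor lies within the scatter) expected. Compound 4 is thus estimated at 50000 nM in this assay, expected between 15000 nM and 150000 nM.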

Compound 4, half-maximal inhibitory concentration: 10200 nM
The estimate for compound 4 lay 4.9-fold (0.69 log units) above the measured number, and the stated range ends above it.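

In this assay, 3,4-difluorobenzyl on the amine nitrogen in a ring gives a number where propargyl and hydrogen left only a limit, with an at least 9.8-fold lower number from compound 3 to compound 4 (0.99 log units; beyond the scatter) and an at least 9.8-fold lower number from compound 1 to compound 4 (0.99 log units; beyond the scatter). This group also goes further than the (4-cyanophenyl)sulfonyl of compound 2, with a 4.3-fold lower number from compound 2 to compound 4 (0.64 log units; beyond the scatter), so the two aryl-bearing groups at this position are not alike. The full size of the first two steps stays unknown because each starts from a limit: the limit of > 100000 nM in this assay, at which 2 of the 4 values shown sit.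

As far as these compounds go, whether a plain benzyl on this nitrogen would give the same number stays open, so the share of the two fluorines in the step cannot be told.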